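Replacing 6-(furan-2-yl)pyridin-3-yl with 2-aminophenyl

The compounds below may be only part of what the source reports. "The series", "measured", "known", "first", "only" and "open" are said of these compounds alone.

- Compound 1 `NC1CCC(Nc2nc(NCc3ccc(Br)cc3)c3ncn(C4CCCC4)c3n2)CC1` gives 850 nM in a functional assay on MCF7 cells (Homo sapiens) for inhibition, with a stated time of 72 h; a higher number here means a weaker inhibitor, a lower number a stronger inhibitor
- Compound 2 `NC1CCC(Nc2nc(NCc3ccc(-c4ccco4)nc3)c3ncn(C4CCCC4)c3n2)CC1` gives 33 nM in this assay

Compound 2 holds the lower of the two numbers, which makes it the stronger inhibitor of this pair. For the measured compounds named here, the only measured step is large and beyond the scatter: a 26-fold lower number from compound 1 to compound 2 (1.41 log units; beyond the scatter), with 6-(furan-2-yl)pyridin-3-yl in place of 4-bromophenyl.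

Compound 3 `Nc1ccccc1CNc1nc(NC2CCC(N)CC2)nc2c1ncn2C1CCCC1` has not been measured. In it, 2-aminophenyl takes the place of 6-(furan-2-yl)pyridin-3-yl on a saturated chain carbon bound to a nitrogen on an aromatic ring (2-aminophenyl in place of 6-(furan-2-yl)pyridin-3-yl on a saturated chain carbon bound to a nitrogen on an aromatic ring). Compound 3 again carries one six-membered aromatic ring of carbon only at this place, as compound 1 does (850 nM), so most of that gain is expected to be lost. Going by the values given here, no measured compound carries 2-aminophenyl, so the estimate is loose. In this assay the expected change is a rise beyond the scatter, an 18-fold higher number from compound 2 to compound 3 (1.26 log units; beyond the scatter), towards a weaker inhibitor. The estimate for compound 3 is 600 nM (expected range 150 nM to 2500 nM).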

Compound 3, half-maximal inhibitory concentration: 2330 nM
Estimate against measurement, compound 3: 3.9-fold (0.59 log units) below; the measured number falls inside the stated range.
By their numbers in this assay, from the lowest: compound 2; then compound 1; then compound 3.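

In this assay the change to 2-aminophenyl gives a 71-fold higher number from compound 2 to compound 3 (1.85 log units; beyond the scatter) at this place, so the low number of compound 2 does not survive this swap. Among groups with one six-membered aromatic ring of carbon only, the choice still counts: 2-aminophenyl in place of 4-bromophenyl gives a 2.7-fold higher number from compound 1 to compound 3 (0.44 log units; beyond the scatter) and shows that the two groups do not read the same, although this step is far smaller than the one from compound 2. Nothing measured here explains either step.

The furan and the pyridine ring enter together in compound 2, so these three compounds cannot show what each contributes. A plain pyridin-3-yl group or a 6-phenylpyridin-3-yl group at this place would help to separate the two rings.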